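Methyl in Place of Hydrogen at a Shared Limit

A few compounds are considered here, and "the series" means these few. Any claim that something is new, unique, unknown or untested is made for them only; others in the source may bear on it.

Measured compounds:
compound 1, `O=C(/C=C/c1ccc(OCCCCCO[N+](=O)[O-])c(O)c1)OCCCCCO[N+](=O)[O-]`, > 50000 nM
compound 2, `O=C(/C=C/c1ccc(OCCCCO[N+](=O)[O-])c(O)c1)OCCCCO[N+](=O)[O-]`, > 50000 nM
compound 3, `COc1cc(/C=C/C(=O)OCCCCCO[N+](=O)[O-])ccc1OCCCCCO[N+](=O)[O-]`, > 50000 nM

In a functional assay on H266 cells (Homo sapiens) for cytotoxicity, read by resazurin assay, with a stated time of 72 h (a higher number here means a weaker inhibitor, a lower number a stronger inhibitor), compound 1 gives only a limit, > 50000 nM. Compound 2 also gives only a limit in this assay. Compound 3 likewise gives only a limit. The change from compound 1 to compound 3, (methyl in place of hydrogen on an oxygen on an aromatic ring), gives a step that the two limits leave unreadable from compound 1 to compound 3, because of the limit of > 50000 nM in this assay, at which 3 of the 3 values shown sit. The difference between the cores of compound 1 and compound 2 is not broken down here. Compound 4, `COc1cc(/C=C/C(=O)OCCCCO[N+](=O)[O-])ccc1OCCCCO[N+](=O)[O-]`, is not yet measured; it arises from compound 2 by the same change, (methyl in place of hydrogen on an oxygen on an aromatic ring). Since all three values shown sit at the limit, a similar step is expected, a step that the limit leaves unreadable from compound 2 to compound 4. Compound 4 is therefore estimated at 100000 nM in this assay, between 50000 nM and 300000 nM.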

Compound 4, half-maximal inhibitory concentration: > 50000 nM
Compound 4 was reported as a limit; the forecaster's own chance of this, stated with the estimate: 90%; the middle value does not contradict the limit.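

Compound 2 and compound 4 both give only a limit, so no size can be read for the step from hydroxy to methoxy between them: the limit of > 50000 nM in this assay, at which 4 of the 4 values shown sit.

The compounds shown leave open whether this change has any effect in this assay.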